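From tert-butyl to iodo: compound 3 to compound 4

The source may hold more compounds than are shown below. What is called first, only, known or untested is meant among the compounds shown, and "the series" means these compounds.

Measured in an ADME assay on MDBK cells (Bos taurus) for cytotoxicity; a higher number here means that more compound is tolerated, a lower number that less compound is tolerated:
- Compound 1 `c1ccc(Cn2ccc3nc(-c4ccccc4)nc-3c2)cc1`: > 100000 nM, a limit
- Compound 2 `N#Cc1ccccc1Cn1ccc2nc(-c3ccccc3)nc-2c1`: > 100000 nM, a limit
- Compound 3 `CC(C)(C)c1ccc(Cn2ccc3nc(-c4ccccc4)nc-3c2)cc1`: 22000 nM

Among these three, only compound 3 has a true number, 22000 nM. The other two values are limits. Compound 4 `Ic1ccc(Cn2ccc3nc(-c4ccccc4)nc-3c2)cc1` differs from compound 3 in one place: iodo in place of tert-butyl on an aromatic carbon. The most relevant evidence is an at least 4.5-fold lower number from compound 1 to compound 3 (0.65 log units; beyond the scatter), which brought in the tert-butyl group. The other measured step, a step that the two limits leave unreadable from compound 1 to compound 2, adds nothing on size. With tert-butyl gone, part of the drop seen in an at least 4.5-fold lower number from compound 1 to compound 3 (0.65 log units; beyond the scatter) is expected to reverse, giving a higher number in this assay, possibly reaching (the limit of > 100000 nM in this assay, at which 2 of the 3 values shown sit). The expected change is a 2.3-fold higher number from compound 3 to compound 4 (0.36 log units; beyond the scatter). For compound 4 the estimated value is 50000 nM, with an expected range of 20000 nM to 100000 nM.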

Compound 4, half-maximal cytotoxic concentration: 22000 nM
Estimate against measurement, compound 4: 2.3-fold (0.36 log units) above; the range from low to high includes it.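

In this assay there is no change at the digits printed from compound 3 to compound 4 (within the scatter), so the lower number is not tied to tert-butyl alone: iodo, with one heavy atom in place of four, goes with it as well. Iodo in place of hydrogen gives an at least 4.5-fold lower number from compound 1 to compound 4 (0.65 log units; beyond the scatter), and 4-iodophenyl in place of 2-cyanophenyl gives an at least 4.5-fold lower number from compound 2 to compound 4 (0.65 log units; beyond the scatter). Both steps start from a limit, so their full size stays unknown: the limit of > 100000 nM in this assay, at which 2 of the 4 values shown sit.

Going by these compounds, what remains open is whether any other group on this aromatic carbon, such as fluoro, methoxy or an amine, would also lower the number.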